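This account rests on a few compounds, and the source may have more. Where it says the series, first, only, none or still open, it means among the compounds named here.

Notes on the series, read in a functional assay on DU-145 cells (Homo sapiens) for cytotoxicity, read by sulforhodamine B assay, with a stated time of 48 h; a higher number here means a weaker inhibitor, a lower number a stronger inhibitor. Compound 1 `C[C@H]1CC[C@@H]2[C@@H](OC(=O)[C@]23CC(c2ccccc2)=NO3)[C@]2(C)C(=O)C=C[C@@]12O` gives 39800 nM, and compound 2 `C[C@H]1CC[C@@H]2[C@@H](OC(=O)[C@]23CC(c2ccc([N+](=O)[O-])cc2)=NO3)[C@]2(C)C(=O)C=C[C@@]12O` gives 7000 nM, the lower of the two numbers. Going by the values given here, only one measured step exists, a 5.7-fold lower number from compound 1 to compound 2 (0.75 log units; beyond the scatter), a modest change beyond the scatter, with nitro in place of hydrogen on an aromatic carbon.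

Compound 3 `COc1cc(C2=NO[C@]3(C2)C(=O)O[C@@H]2[C@H]3CC[C@H](C)[C@]3(O)C=CC(=O)[C@@]23C)ccc1O` has not been measured. Its difference is 4-hydroxy-3-methoxyphenyl in place of 4-nitrophenyl on a carbon with a double bond to nitrogen. Compound 3 has no nitro, so the measured step of a 5.7-fold lower number from compound 1 to compound 2 (0.75 log units; beyond the scatter) suggests a partial return toward compound 1. Among the compounds with values here, no measured compound shows what 4-hydroxy-3-methoxyphenyl itself does, so the expectation is loose. The estimated step is a 2.6-fold higher number from compound 2 to compound 3 (0.41 log units; beyond the scatter), of similar or smaller size than the measured one and toward a higher number. For compound 3 the expected value is 18000 nM, with an estimated range of 5500 nM to 50000 nM.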

Compound 3, half-maximal inhibitory concentration: 71000 nM
Estimate against measurement, compound 3: 3.9-fold (0.60 log units) below, outside the stated range (above it).
By their numbers in this assay, from the lowest: compound 2; then compounds 1 and 3 (each within the scatter of the next).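

On a carbon with a double bond to nitrogen, 4-hydroxy-3-methoxyphenyl in place of 4-nitrophenyl gives a 10-fold higher number from compound 2 to compound 3 (1.01 log units; beyond the scatter) in this assay and thus a large step, so the lower number belongs to compound 2 alone among the three. Against phenyl, the same group gives a 1.8-fold higher number from compound 1 to compound 3 (0.25 log units; within the scatter) and stays within the scatter, so compound 1 and compound 3 cannot be ordered, and this substitution shows no measurable change from the plain phenyl. No measured information on these groups bears on this result.

Going by these compounds alone, whether the lower number of compound 2 is specific to nitro remains open, since only one substituted ring reads lower than phenyl. The hydroxy and methoxy groups appear only together, and neither alone nor an amine or a carboxylic acid on the phenyl ring is shown here.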